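The compounds below may be only part of what the source reports. "The series", "measured", "known", "first", "only" and "open" are said of these compounds alone.

Three compounds of this series have a number in an assay on HEK293 cells for displacement of a labelled ligand from prostaglandin D2 receptor 2 (Homo sapiens); a lower number here means a stronger inhibitor, a higher number a weaker inhibitor. Compound 1 `COC(=O)c1ccc(CSc2nc3ccccc3n2CC(=O)O)cc1` gives 10600 nM. Compound 2 `CC(=O)c1cccc(CSc2nc3ccccc3n2CC(=O)O)c1` gives 230 nM. Compound 3 `COc1ccc(C(=O)c2ccccc2)cc1CSc1nc2cc(F)ccc2n1CC(=O)O` gives 1.7 nM, the lowest of the three; the gap to compound 2 and the larger gap to compound 1 both lie beyond the scatter, so compound 3 stands apart as the strongest inhibitor among the measured compounds. Among the measured compounds shown here, compound 3 differs from the other two in more than one place at once, so no single step between measured compounds can be read off from these three numbers.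

Compound 4 `COc1ccc(C(=O)NCc2ccccc2)cc1CSc1nc2cc(F)ccc2n1CC(=O)O` keeps the rest of compound 3 unchanged and alters only the group on the carbonyl: benzylamino in place of phenyl on a carbonyl carbon. For the measured compounds named here, no measured pair shows a change of this kind, so its effect is not known from the data. The rewrite of the ketone into an amide carrying a benzylamino group is taken here as a change of moderate size, more likely to raise the number in this assay than to lower it, and the expected step is a 2.9-fold higher number from compound 3 to compound 4 (0.47 log units; beyond the scatter). Compound 4 is accordingly estimated at 5 nM in this assay, with a range from 1.5 nM to 25 nM.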

Compound 4, half-maximal inhibitory concentration: 59 nM
Beside the measured number, compound 4's estimate is 12-fold (1.07 log units) below it, outside the stated range (above it).
By their numbers in this assay, from the lowest: compound 3; then compound 4; then compound 2; then compound 1.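

Among the compounds shown here, the group on the carbonyl carbon is the first place where a single change can be read: in this assay benzylamino in place of phenyl gives a 35-fold higher number from compound 3 to compound 4 (1.54 log units; beyond the scatter) and this large step lies beyond the scatter. The number at this position therefore depends strongly on what stands on the carbonyl, and the six-membered aromatic ring present in both phenyl and benzylamino does not by itself preserve the number of compound 3 when the group changes from benzoyl to benzylcarbamoyl. The compounds shown offer no measurement that explains the size or direction of this step.

Still open, from the compounds shown here alone, is which part of the exchange carries the step: the amide hydrogen, which benzylamino brings as a hydrogen-bond donor, or the longer link to its ring. Phenylamino on the same carbonyl carbon, which keeps the amide hydrogen without the benzyl carbon, and dimethylamino, which has neither the amide hydrogen nor a ring, would help to separate these two parts of the change.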